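Piperidine for Piperazine on Bornyl Esters and Amides

The source may hold more compounds than are shown below. What is called first, only, known or untested is meant among the compounds shown, and "the series" means these compounds.

Compound 1 `CC1CCN(CCCC(=O)O[C@@H]2C[C@@H]3CC[C@@]2(C)C3(C)C)CC1`: 171000 nM
Compound 2 `CN1CCN(CCCC(=O)O[C@@H]2C[C@@H]3CC[C@@]2(C)C3(C)C)CC1`: 99200 nM
Compound 3 `CN1CCN(CCC(=O)N[C@@H]2C[C@H]3CC[C@]2(C)C3(C)C)CC1`: 486000 nM

In an ADME assay on HEK-293T cells (Homo sapiens) for cytotoxicity, read by MTT assay, with a stated time of 48 h (on this read-out higher numbers stand for lower toxicity in this test and lower numbers for higher toxicity in this test), compound 3 gives 486000 nM and compound 2 gives 99200 nM; the difference between the two cores is not broken down here. Compound 1 differs from compound 2 by 4-methylpiperidin-1-yl in place of 4-methylpiperazin-1-yl on a saturated chain carbon, three bonds along the chain from a carbonyl carbon, and the step of a 1.7-fold higher number from compound 2 to compound 1 (0.24 log units; within the scatter). Compound 4 `CC1CCN(CCC(=O)N[C@@H]2C[C@H]3CC[C@]2(C)C3(C)C)CC1` is not yet measured; it differs from compound 3 by 4-methylpiperidin-1-yl in place of 4-methylpiperazin-1-yl on a saturated chain carbon, two bonds along the chain from a carbonyl carbon. The place differs, two bonds along the chain from a carbonyl carbon rather than three, so this is the same kind of change, not the same one. Because the earlier step of a 1.7-fold higher number from compound 2 to compound 1 (0.24 log units; within the scatter) stayed within the scatter, a similar small step is expected here, a 1.3-fold higher number from compound 3 to compound 4 (0.11 log units; within the scatter). Compound 4 is therefore estimated to give 620000 nM in this assay, between 250000 nM and 1500000 nM.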

Compound 4, half-maximal cytotoxic concentration: 93600 nM
The estimate for compound 4 lay 6.6-fold (0.82 log units) above the measured number; the whole stated range lies above it.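

In this assay, 4-methylpiperidin-1-yl in place of 4-methylpiperazin-1-yl gives a 5.2-fold lower number from compound 3 to compound 4 (0.72 log units; beyond the scatter), a step beyond the scatter. The same kind of change therefore did not carry over from the core of compound 2 to the core of compound 3: the same change on two cores in this assay, a 1.7-fold higher number (0.24 log units; within the scatter) from compound 2 to compound 1 and a 5.2-fold lower number (0.72 log units; beyond the scatter) from compound 3 to compound 4, 9.0-fold (0.95 log units) apart, beyond the scatter of two such steps. This shows that, in this series, the step seen on one core cannot simply be applied to the other, but it does not show which difference between the cores separates the two steps, and one pair per core supports no general rule.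

The compounds shown leave open whether an amide in place of the ester, on an otherwise unchanged chain, would alter the step. They also leave open how a morpholin-4-yl group in the same place would compare on either core.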